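A few compounds are considered here, and "the series" means these few. Any claim that something is new, unique, unknown or untested is made for them only; others in the source may bear on it.

Measured compounds:
compound 1 `N#Cc1c(Nc2cccc(C(F)(F)F)c2)nc(SCc2cn(Cc3ccccc3Cl)nn2)nc1-c1ccccc1` — 32000 nM
compound 2 `N#Cc1c(Nc2ccccc2F)nc(SCc2cn(Cc3ccccc3Cl)nn2)nc1-c1ccccc1` — 23000 nM
compound 3 `N#Cc1c(Nc2ccc(F)cc2)nc(SCc2cn(Cc3ccccc3Cl)nn2)nc1-c1ccccc1` — 25800 nM

All three were tested in a functional assay on ECa-109 cells (Homo sapiens) for inhibition, read by MTT assay, with a stated time of 72 h; a higher number here means a weaker inhibitor, a lower number a stronger inhibitor. Compound 2 stands at the low end of the three numbers, but a 1.1-fold higher number from compound 2 to compound 3 (0.05 log units; within the scatter) and a 1.4-fold lower number from compound 1 to compound 2 (0.14 log units; within the scatter) both fall within the scatter, so the three compounds cannot be separated on these values. The same holds for a 1.2-fold lower number from compound 1 to compound 3 (0.09 log units; within the scatter). Every measured step changes only the aryl group on a nitrogen on an aromatic ring; the benzyl portion is identical across compounds 1, 2 and 3.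

Compound 4 `Cc1ccc(Cn2cc(CSc3nc(Nc4ccccc4F)c(C#N)c(-c4ccccc4)n3)nn2)cc1` is not yet measured. It differs from compound 2 in that portion: 4-methylphenyl in place of 2-chlorophenyl on a saturated chain carbon bound to an aromatic nitrogen. Going by the values given here, no measured step bears on this position, and the steps that do exist are all within the scatter. There is therefore no basis for expecting a step beyond the scatter in either direction, and the estimate for compound 4 is no change at the digits printed from compound 2 to compound 4 (within the scatter), carrying a wide range. Compound 4 is expected to give 23000 nM in this assay, between 8000 nM and 65000 nM.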

Compound 4, half-maximal inhibitory concentration: > 64000 nM
Compound 4: no number, only a limit; the forecaster's own chance of this, stated with the estimate: 10%; at least 2.7-fold (0.44 log units) between middle value and limit.
By their numbers in this assay, from the lowest: compounds 2, 3 and 1 (each within the scatter of the next). At a limit, above all of these: compound 4.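

Going by these compounds alone, exchanging 2-chlorophenyl for 4-methylphenyl on a saturated chain carbon bound to an aromatic nitrogen gives, in this assay, an at least 2.7-fold higher number from compound 2 to compound 4 (0.44 log units; beyond the scatter), the only step of this size. The earlier steps shown here, all on the aryl group on a nitrogen on an aromatic ring, stayed within the scatter and said nothing about this position, which now proves sensitive to the group it carries, at least for this one change. Compound 4 gives only a limit of the assay, so the full size of the step stays unknown: the limit of > 64000 nM in this assay, at which 1 of the 4 values shown sits.

This single change alters both the substituent and its place on the phenyl ring, and the compounds shown do not separate the two. As far as these compounds go, how 2-methylphenyl, 4-chlorophenyl, or a phenyl bearing a carboxylic acid or an amine would read at this position remains open.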